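The source may report more compounds than this note shows. Statements on the series, on what has been measured and on what is new or still open speak of the compounds shown alone.

Compound 1, `c1ccc(-c2cn3ccnc3c(-c3ccc4ncn(C5CCCCC5)c4c3)n2)cc1`, is the reference point of this small set. In a functional assay on A498 cells (Homo sapiens) for inhibition, read by sulforhodamine B assay, with a stated time of 48 h, tested at 10 uM (on this read-out higher numbers stand for more inhibition at the one concentration tested (going by the name of the read-out) and lower numbers for less inhibition), compound 1 gives 26.1%, the highest of the three numbers; compound 3, `c1cn2cc(-c3ccsc3)nc(-c3ccc4ncn(C5CCCCC5)c4c3)c2n1`, gives 20.1%, and compound 2, `COc1ccc(-c2cn3ccnc3c(-c3ccc4ncn(C5CCCCC5)c4c3)n2)cc1`, gives -12.3%. The step of a number 6 percentage points lower from compound 1 to compound 3 (within the scatter) lies within the scatter, whereas a number 38.4 percentage points lower from compound 1 to compound 2 (beyond the scatter) and a number 32.4 percentage points higher from compound 2 to compound 3 (beyond the scatter) are both large.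

Compound 4, `COc1ccccc1-c1cn2ccnc2c(-c2ccc3ncn(C4CCCCC4)c3c2)n1`, differs from compound 1 by methoxy in place of hydrogen on an aromatic carbon. For the measured compounds named here, the same kind of change, methoxy in place of hydrogen on an aromatic carbon, is the one measured step that bears on it, though at a different place on the ring: there it produced the large drop a number 38.4 percentage points lower from compound 1 to compound 2 (beyond the scatter). Whether a methoxy ortho to a large group behaves like that is not shown by any measured pair, so the expectation rests on a single step at another position and carries a wide range.

A downward step of a number 21.1 percentage points lower from compound 1 to compound 4 (beyond the scatter) is therefore expected, smaller than the measured one because a number 38.4 percentage points lower from compound 1 to compound 2 (beyond the scatter) was seen at another position on the ring, and compound 4 is estimated to give 5% in this assay, in a range from -20% to 30%.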

Compound 4, a percentage reported as inhibition, at one concentration (the size of the read-out at that concentration, not a potency): 13.9%
The estimate for compound 4 lay 8.9 percentage points below the measured number; measured number inside the range.
By their numbers in this assay, from the lowest: compound 2; then compounds 4, 3 and 1 (each within the scatter of the next, the first and the last beyond it).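

Set side by side in this assay, the two methoxy steps show that the effect of this change depends on where it sits on the phenyl ring: with the methoxy ortho to a large group the step is a number 12.2 percentage points lower from compound 1 to compound 4 (beyond the scatter), against a number 38.4 percentage points lower from compound 1 to compound 2 (beyond the scatter), and the two methoxy isomers are themselves separated by a number 26.2 percentage points higher from compound 2 to compound 4 (beyond the scatter), beyond the scatter. The earlier compounds shown here offered only one methoxy position, so they could not show that a modest loss was possible with this group on the ring. Compound 4 also stands level with the thiophene compound, with a number 6.2 percentage points lower from compound 3 to compound 4 (within the scatter) leaving 2-methoxyphenyl and thiophen-3-yl indistinguishable here, and nothing available accounts for the difference between the two methoxy positions.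

The compounds shown leave open whether a longer chain, such as ethoxy, at the same place would follow the methoxy result, and whether an amine or a carboxylic acid there would do the same. They also leave open how these compounds would rank at other concentrations, since every number comes from a single tested concentration.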